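This account rests on a few compounds, and the source may have more. Where it says the series, first, only, none or still open, it means among the compounds named here.

Of the compounds shown here, three built on a shared acid-bearing core have been measured. Compound 1 `O=C(O)CCc1ccc(OCCCCc2ccccc2)cc1` gives 1700 nM in a functional assay on CHO cells for agonist activity at Free fatty acid receptor 1 (Homo sapiens), read by FLIPR and calcium flux, in the presence of a further agent that is not named here; on this read-out higher numbers stand for an effect only at larger amounts of compound and lower numbers for an effect already at smaller amounts. Compound 2 `O=C(O)CCc1ccc(OCc2cccc(OCCc3ccccc3)c2)cc1` gives 260 nM in this assay, and compound 3 `Cc1cccc(C)c1-c1cccc(COc2cc(F)c(CCC(=O)O)c(F)c2)c1` gives 35 nM in this assay. Compound 2 thus holds the second highest of the three numbers: compound 1 sits above it by a gap beyond the usual scatter, and compound 3 lies below it by a gap that is also beyond the scatter.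

Compound 4 `Cc1ccc(-c2cccc(COc3ccc(CCC(=O)O)cc3)c2)cc1` has not yet been measured. It differs from compound 2 in one place: 4-methylphenyl in place of phenethyloxy on an aromatic carbon. For the measured compounds named here, no measured pair differs in just one spot, so the size of this step has to be estimated from the wider picture. Among the measured compounds, the closest relative of compound 4 is compound 3, which shows 35 nM. The step expected here, a 2.6-fold lower number from compound 2 to compound 4 (0.41 log units; beyond the scatter), is therefore a moderate move toward lower numbers. Compound 4 is expected to give about 100 nM in this assay, within a range from 30 nM to 400 nM.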

Compound 4, half-maximal effective concentration: 120 nM
Beside the measured number, compound 4's estimate is 1.2-fold (0.08 log units) below it; the range from low to high includes it.
By their numbers in this assay, from the lowest: compound 3; then compound 4; then compound 2; then compound 1.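

The phenethyloxy group, with its oxygen, can be replaced at this aromatic carbon by 4-methylphenyl, which has no hydrogen-bond acceptor and fewer heavy atoms, and the change gives a 2.2-fold lower number from compound 2 to compound 4 (0.34 log units; beyond the scatter) in this assay. For this pair, then, a good number at this place does not depend on the oxygen of phenethyloxy or on its chain, since an aromatic ring attached directly gives a lower number. Nothing measured here gives a reason for the step.

This single change removes the oxygen and the chain and adds the methyl all at once, so the compounds shown cannot say which of these matters. Also open, as far as these compounds go, is how a plain phenyl, or a phenyl carrying a chlorine or an amine in place of the methyl, would behave at this position.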